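The source may hold more compounds than are shown below. What is called first, only, known or untested is meant among the compounds shown, and "the series" means these compounds.

For the measured compounds named here, in a functional assay on A-375 cells (Homo sapiens) for inhibition, read by CCK-8 assay, with a stated time of 72 h, tested at 8 uM (a higher number here means more inhibition of growth at the concentration tested, a lower number less inhibition of growth), compound 1 (`Cc1ccc(SCc2ccc(C(=O)Nc3ccccc3N)cc2)cc1`) gives 67% and compound 2 (`Nc1ccccc1NC(=O)c1ccc(CSc2ccc(Br)cc2)cc1`) gives 6.17% as the lower of the two numbers so far. Compound 3 (`Nc1ccccc1NC(=O)c1ccc(CSc2ccc(F)cc2)cc1`) keeps the rest of compound 2 and carries fluoro in place of bromo on an aromatic carbon, para to a large group (fluoro in place of bromo on an aromatic carbon). Going by the values given here, one measured step bears on this change: a number 60.8 percentage points lower from compound 1 to compound 2 (beyond the scatter) for bromo in place of methyl at the same place. Among the compounds with values here, no fluoro compound has been measured yet, so that large step guides the direction only loosely. A sizeable rise in this assay is expected, smaller than the step between compound 1 and compound 2. The expected move is a number 28.8 percentage points higher from compound 2 to compound 3 (beyond the scatter) as an estimate. Compound 3 is expected at 35% with 8% to 68% as the estimated range.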

Compound 3, percent growth inhibition at one concentration: 54.3%
The estimate for compound 3 lay 19.3 percentage points below the measured number, and the stated range covers the measured number.
By their numbers in this assay, from the lowest: compound 2; then compound 3; then compound 1.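

In this assay the step of a number 48.1 percentage points higher from compound 2 to compound 3 (beyond the scatter) is large and shows that the low number of compound 2 does not extend to every replacement of methyl at this place on the ring. The step of a number 12.7 percentage points lower from compound 1 to compound 3 (beyond the scatter) is modest but beyond the scatter, so fluoro retains much of the inhibition seen with methyl without matching it, and 4-fluorophenyl stands closer to 4-methylphenyl than to 4-bromophenyl in this series. Nothing available explains why bromo and fluoro differ so widely here.

On these data alone, whether the sharp loss is particular to bromo or also occurs with chloro at the same place remains open, as does the outcome with a methoxy group or an amine there. All three compounds keep the sulfanyl link, so it is also unknown whether this order persists with an oxygen link in its place.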